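This account rests on a few compounds, and the source may have more. Where it says the series, first, only, none or still open, it means among the compounds named here.

Compound 2 `Cc1ccc(S(=O)(=O)NC(=O)Nc2ccccc2C(=O)/C=C/c2ccc(F)cc2)cc1` gives the lowest of the two numbers in an ADME assay on the whole organism for cytotoxicity, with Artemia salina as the target, with a stated time of 24 h (on this read-out higher numbers stand for an effect only at larger amounts of compound and lower numbers for an effect already at smaller amounts), at 3.96 ug/mL; the nearest is compound 1 `COc1cccc(/C=C/C(=O)c2ccccc2NC(=O)NS(=O)(=O)c2ccc(C)cc2)c1`, which in this assay gives 23.2 ug/mL. Among the compounds with values here, the single step between them, a 5.9-fold lower number from compound 1 to compound 2 (0.77 log units; beyond the scatter), came from a different aryl exchange. Compound 3 `Cc1ccc(S(=O)(=O)NC(=O)Nc2ccccc2C(=O)/C=C/c2ccc(Cl)cc2Cl)cc1` differs from compound 2 by 2,4-dichlorophenyl in place of 4-fluorophenyl on a double-bonded chain carbon bound to a double-bonded chain carbon. Within the data shown here, no measured step bears directly on this change, so only a step within the scatter is expected: the estimate for the move from compound 2 to compound 3 in this assay is a 1.1-fold lower number from compound 2 to compound 3 (0.05 log units; within the scatter). For compound 3 in this assay the value is estimated at 3.5 ug/mL, within a range of 1.2 ug/mL to 10 ug/mL.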

Compound 3, concentration for half-maximal effect: 8.34 ug/mL
Estimate against measurement, compound 3: 2.4-fold (0.38 log units) below; the measured number falls inside the stated range.
By their numbers in this assay, from the lowest: compound 2; then compound 3; then compound 1.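

In this assay, the number at this chain carbon still shifts when one halogen-bearing ring replaces another: 2,4-dichlorophenyl in place of 4-fluorophenyl gives a 2.1-fold higher number from compound 2 to compound 3 (0.32 log units; beyond the scatter) within the halogen-bearing pair. The same 2,4-dichlorophenyl in place of 3-methoxyphenyl gives a 2.8-fold lower number from compound 1 to compound 3 (0.44 log units; beyond the scatter) and so keeps both halogen-bearing rings lower than the methoxy-bearing one. Nothing measured here accounts for these differences. The compounds shown leave open where 4-chlorophenyl would fall, so the contributions of the two chlorines cannot be separated. Also open, on these data alone, is how unsubstituted phenyl or an aminophenyl would read at this place.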